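Bromo to chloro on compound 1

A few compounds are considered here, and "the series" means these few. Any claim that something is new, unique, unknown or untested is made for them only; others in the source may bear on it.

Three compounds have numbers in a functional assay on SK-BR-3 cells (Homo sapiens) for inhibition; on this read-out higher numbers stand for weaker inhibition and lower numbers for stronger inhibition. Compound 1 `Cc1cnc(CN2CC(=O)N(CC(C)C)c3c(Cl)nc(N)nc32)c(C)c1Br` gives 60 nM, the second highest of the three. Compound 2 `COc1c(C)cnc(CN2CC(=O)N(C(C)C(=O)NCCN(C)C)c3c(Cl)nc(N)nc32)c1C` gives 30 nM, which lies within the scatter of compound 1. Compound 3 `COc1c(C)cnc(CN2c3nc(N)nc(Cl)c3NC(=O)[C@@H]2CC(C)C)c1C` gives 230 nM, a gap from compound 1 that goes beyond the scatter. Within the data shown here, no pair of measured compounds differs in a single place, so the exchange of one halogen for another has no measured precedent in this set. Compound 4 `Cc1cnc(CN2CC(=O)N(CC(C)C)c3c(Cl)nc(N)nc32)c(C)c1Cl` differs from compound 1 in one place: chloro in place of bromo on an aromatic carbon. With no measured guide, the change is expected to give only a small step in this assay, a 1.3-fold higher number from compound 1 to compound 4 (0.12 log units; within the scatter), most likely not beyond the scatter. Compound 4 is therefore estimated at 80 nM, within a range from 30 nM to 200 nM.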

Compound 4, half-maximal inhibitory concentration: 110 nM
Beside the measured number, compound 4's estimate is 1.4-fold (0.14 log units) below it; measured number inside the range.
By their numbers in this assay, from the lowest: compounds 2, 1 and 4 (each within the scatter of the next, the first and the last beyond it); then compound 3.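

Chloro in place of bromo, opposite the ring nitrogen and ortho to two methyl groups, is the first single-place exchange in the set, and in this assay it gives a step (a 1.8-fold higher number from compound 1 to compound 4 (0.26 log units; within the scatter)) that stays within the scatter. On this single pair, the two halogens cannot be told apart at this position. Nothing available explains the size of this step.

As far as these compounds go, whether fluoro, a nitrile or an amine at this position would also stay within the scatter of compound 1 remains open. So does whether the same exchange gives a similar step with a group other than the isobutyl-bearing core of compound 1.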